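Flavanone series: aryl swap at the saturated ring carbon

The compounds below may be only part of what the source reports. "The series", "measured", "known", "first", "only" and "open" are said of these compounds alone.

Compound 1 `Cc1c(O)c(C)c2c(c1O)C(=O)CC(c1ccccc1O)O2` is the reference. In a functional assay on VSMC cells (Rattus norvegicus) (on this read-out lower numbers stand for stronger inhibition and higher numbers for weaker inhibition), compound 1 is recorded as "not active" (no number reported), so no single number marks where it stands. Compound 2 `Cc1c(O)c(C)c2c(c1O)C(=O)CC(c1ccccc1[N+](=O)[O-])O2` gives a weak 9900 nM in this assay, the only numeric anchor in the set. Compound 3 `Cc1c(O)c(C)c2c(c1O)C(=O)CC(c1ccco1)O2` carries the change (furan-2-yl in place of 2-hydroxyphenyl on a saturated ring carbon). Within the data shown here, with no measured step in this assay to compare, a small step toward stronger inhibition at most is expected, possibly none beyond the scatter, with compound 3 remaining weak like compound 2. Compound 3 is expected near 12000 nM, estimated between 3000 nM and 50000 nM.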

Compound 3, half-maximal inhibitory concentration: 6700 nM
Estimate against measurement, compound 3: 1.8-fold (0.25 log units) above, and the stated range covers the measured number.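

In this assay, among these compounds, compound 1 has no number, so no step to compound 3 can be read. On these data alone, how far furan-2-yl in place of 2-hydroxyphenyl shifts inhibition stays open. No evidence on hand bears on this result.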